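Hepatic extraction in the thiazole amide series: cyano to chloro

The source may report more compounds than this note shows. Statements on the series, on what has been measured and on what is new or still open speak of the compounds shown alone.

Compound 2 `CS(=O)(=O)N1CCC[C@H](c2csc(-c3ccccc3NC(=O)c3nc(C#N)c[nH]3)n2)C1` gives 0.67 in an ADME assay on microsomes from liver (Rattus norvegicus) (on this read-out lower numbers stand for lower hepatic extraction and higher numbers for higher hepatic extraction), and stands lowest of the two numbers measured, with compound 1 `Cc1c[nH]c(C(=O)Nc2ccccc2-c2nc([C@H]3CCCN(S(C)(=O)=O)C3)cs2)n1` nearest at 0.71, a gap within the scatter. Among the measured compounds shown here, the one measured step, a number 0.040 lower from compound 1 to compound 2 (within the scatter), is the only point of comparison. Compound 3 `CS(=O)(=O)N1CCC[C@H](c2csc(-c3ccccc3NC(=O)c3nc(Cl)c[nH]3)n2)C1` differs from compound 2 by chloro in place of cyano on an aromatic carbon. Given that a change at the same aromatic carbon moved this assay only within the scatter, compound 3 is expected to give 0.68, between 0.58 and 0.78, a step of a number 0.010 higher from compound 2 to compound 3 (within the scatter) that is not expected to exceed the scatter.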

Compound 3, hepatic extraction ratio: 0.77
Beside the measured number, compound 3's estimate is 0.090 below it; the measured number falls inside the stated range.
By their numbers in this assay, from the lowest: compounds 2, 1 and 3 (each within the scatter of the next).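

In this assay, chloro in place of cyano on this aromatic carbon gives a number 0.10 higher from compound 2 to compound 3 (within the scatter), and chloro in place of methyl gives a number 0.060 higher from compound 1 to compound 3 (within the scatter). Methyl, cyano and chloro at this position therefore all lie within the scatter of one another, so this read-out does not separate chloro from the other two groups here. No available data bear on the reason for these numbers. From the compounds shown here alone, whether an amine or a carboxylic acid on this carbon would move this assay beyond the scatter remains open.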